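The source may hold more compounds than are shown below. What is called first, only, known or untested is meant among the compounds shown, and "the series" means these compounds.

Measured compounds: compound 1, `CC1=C/C(=C\C(C)C)C(=O)C(C)(O)C12CC2`, gives 300 nM in a functional assay on MDA-MB-231 cells (Homo sapiens) for antiproliferative activity; a higher number here means a weaker inhibitor, a lower number a stronger inhibitor; compound 2, `C/C=C1\C=C(C)C2(CC2)C(C)(O)C1=O`, gives 110 nM in this assay.

Compound 2 holds the lower of the two numbers, and it sits clearly apart from compound 1, since the step of a 2.7-fold lower number from compound 1 to compound 2 (0.44 log units; beyond the scatter) lies beyond the scatter. Among the measured compounds shown here, that single step is the only comparison available, and it concerns the same place on the shared core: swapping a larger isopropyl group for a methyl group there made the number drop.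

Compound 3, `CC1=C/C(=C\c2cccs2)C(=O)C(C)(O)C12CC2`, has not yet been measured in this assay. It changes that same place again: thiophen-2-yl in place of methyl on a double-bonded chain carbon bound to a double-bonded ring carbon. For the measured compounds named here, the one measured step points the other way, because a 2.7-fold lower number from compound 1 to compound 2 (0.44 log units; beyond the scatter) shows that shrinking the group at this carbon helped, and compound 3 instead enlarges it, now with an aromatic ring in place of a single carbon. An aromatic ring is not an isopropyl group, so the step cannot simply be read backwards, and the expectation is held loosely. A modest weakening is expected, with a 1.8-fold higher number from compound 2 to compound 3 (0.26 log units; within the scatter) as the estimated step. Compound 3 is therefore estimated at 200 nM, with a range from 60 nM to 700 nM.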

Compound 3, half-maximal inhibitory concentration: > 10000 nM
Compound 3: no number, only a limit; the forecaster's own chance of this, stated with the estimate: 5%; middle value at least 50-fold (1.69 log units) from the limit.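

Among the compounds shown here, changing the group on this double-bonded chain carbon can do far more than the earlier compounds showed, since their only comparison was the modest step between methyl and isopropyl. In this assay, the thiophen-2-yl group gives an at least 90-fold higher number from compound 2 to compound 3 (1.95 log units; beyond the scatter) and an at least 33-fold higher number from compound 1 to compound 3 (1.52 log units; beyond the scatter), so both steps are large and both are minimum sizes, with the true gaps left unknown. Compound 3 gives a limit of the assay and not a number: the limit of > 10000 nM in this assay, at which 1 of the 3 values shown sits.

The compounds shown cannot separate the effect of having an aromatic ring here from anything particular to thiophen-2-yl, such as its sulfur, and a phenyl ring at the same carbon would be one way to draw that line. They also leave open whether the activity falls gradually or abruptly as the group grows from methyl through isopropyl, and whether non-aromatic groups such as a longer chain or a chain ending in an amine would stay close to compound 1 and compound 2 or fall away as compound 3 does.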